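From Benzoyl to Phenylcarbamoyl on a Shared Core

This account rests on a few compounds, and the source may have more. Where it says the series, first, only, none or still open, it means among the compounds named here.

compound 1 `COc1cc(-c2nnc(SCC(=O)c3ccccc3)n2N)cc(OC)c1OC`: 7800 nM
compound 2 `COc1cc(-c2nnc(SCC(=O)c3ccc(F)c(F)c3)n2N)cc(OC)c1OC`: > 100000 nM
compound 3 `COc1cc(-c2nnc(SCC(=O)c3ccccc3F)n2N)cc(OC)c1OC`: 22600 nM

Of the compounds shown here, three on one core have been tested in a functional assay on HepG2 cells (Homo sapiens) for antiproliferative activity, read by MTT assay, with a stated time of 48 h; on this read-out higher numbers stand for weaker inhibition and lower numbers for stronger inhibition. Compound 1 gives 7800 nM, the lowest of the two numbers recorded. Compound 3 gives 22600 nM, and the step of a 2.9-fold higher number from compound 1 to compound 3 (0.46 log units; beyond the scatter) lies beyond the scatter. Compound 2 reaches only a limit of the assay, not a number: the limit of > 100000 nM in this assay, at which 1 of the 3 values shown sits. The steps of an at least 12-fold higher number from compound 1 to compound 2 (1.10 log units; beyond the scatter) and an at least 4.4-fold lower number from compound 2 to compound 3 (0.64 log units; beyond the scatter) both concern fluorine on the phenyl ring.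

Compound 4 `COc1cc(-c2nnc(SCC(=O)Nc3ccccc3)n2N)cc(OC)c1OC` is not yet measured. It differs from compound 1 by anilino in place of phenyl on a carbonyl carbon. Going by the values given here, no measured step touches the carbonyl neighbour in this way; all of them vary fluorine on the phenyl, so none bears directly on this change. The expectation is therefore wide: for compound 4 a value of 12000 nM is estimated, between 3000 nM and 60000 nM, an expected step of a 1.5-fold higher number from compound 1 to compound 4 (0.19 log units; within the scatter).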

Compound 4, half-maximal inhibitory concentration: 49900 nM
Estimate against measurement, compound 4: 4.2-fold (0.62 log units) below, within the range that was stated.
By their numbers in this assay, from the lowest: compound 1; then compound 3; then compound 4. At a limit, above all of these: compound 2.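

In this assay the carbonyl neighbour, untouched by the fluorine steps, turns out to matter: anilino in place of phenyl on a carbonyl carbon gives a 6.4-fold higher number from compound 1 to compound 4 (0.81 log units; beyond the scatter) and, set against 2-fluorophenyl, gives a 2.2-fold higher number from compound 3 to compound 4 (0.34 log units; beyond the scatter). Against 3,4-difluorophenyl only a floor can be read, an at least 2.0-fold lower number from compound 2 to compound 4 (0.30 log units; that floor lies within the scatter), so that pair stays unordered in size. Compound 2 stands at a limit of the assay, not at a number: the limit of > 100000 nM in this assay, at which 1 of the 4 values shown sits.

As far as these compounds go, whether fluoro on the anilino ring would follow the fluorine steps stays open. So does how a benzylamino or cyclohexylamino group in place of anilino would read.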